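The source may hold more compounds than are shown below. What is called first, only, known or untested is meant among the compounds shown, and "the series" means these compounds.

Working notes on the series. Two cores are in hand. Compound 3 `CC(=O)Nc1ccc(-c2nc3cc(C(F)(F)F)ccc3n2C2CCCCC2)cc1` and compound 1 `CCC(=O)Nc1ccc(-c2nc3cc(C(F)(F)F)ccc3n2C2CCCCC2)cc1` share one core; compound 2 `CC(=O)Nc1ccc(-c2nc3ccccc3[nH]2)cc1` carries the other, and the difference between the two cores is not broken down here.

In an ADME assay on BHK cells (Mesocricetus auratus) for cytotoxicity, read by MTT assay, with a stated time of 96 h (on this read-out lower numbers stand for higher toxicity in this test and higher numbers for lower toxicity in this test), compound 3 gives 15000 nM. In this assay compound 1 gives 15000 nM. The step of no change at the digits printed from compound 3 to compound 1 (within the scatter) belongs to the change (methyl in place of hydrogen on a saturated chain carbon bound to a carbonyl carbon), so on this core the change leaves the read-out where it was.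

Compound 2 reaches only a limit of this assay and gives > 100000 nM. This is the limit described as the limit of > 100000 nM in this assay, at which 1 of the 3 values shown sits, and it is a limit and not a number.

Compound 4 `CCC(=O)Nc1ccc(-c2nc3ccccc3[nH]2)cc1` is still to be measured in this assay. It differs from compound 2 by methyl in place of hydrogen on a saturated chain carbon bound to a carbonyl carbon, the same change as from compound 3 to compound 1; the place is described in the same words for both pairs, so it is the same change made on the second core.

The expected step from compound 2 to compound 4 is a number no higher from compound 2 to compound 4 (the limit leaves the size open), resting on the measured step of no change at the digits printed from compound 3 to compound 1 (within the scatter), which showed no movement, and on the fact that compound 2 already sits at a limit. For compound 4 the expected value in this assay is 100000 nM, within 50000 nM to 200000 nM, and most likely the assay again reports only a limit for compound 4.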

Compound 4, half-maximal cytotoxic concentration: >= 100000 nM
Compound 4 gave a limit, no number (the forecaster's own chance of this, stated with the estimate: 80%); the middle value sits exactly at the limit.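

Among these compounds, compound 2 and compound 4 both stand at a limit in this assay, not at a number, and no step between them can be read. The compounds shown leave open whether the change from acetamido to propanoylamino moves the read-out at all on the core of compound 2, as no number stands on either side of that pair.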